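From 2-hydroxyethyl to 2-methoxyethyl on compound 1

A few compounds are considered here, and "the series" means these few. Any claim that something is new, unique, unknown or untested is made for them only; others in the source may bear on it.

- Compound 1 `Cc1ccccc1N1C(=O)/C(=C/c2ccc(O)c(Cl)c2)S/C1=N\CCO`: 1.9
- Compound 2 `CCC/N=C1\S/C(=C\c2ccc(O)c(Cl)c2)C(=O)N1C(C)C`: > 4.3 (a limit of the assay, not a number)
- Compound 3 `CCC/N=C1\S/C(=C\c2ccc(O)c(Cl)c2)C(=O)N1c1ccccc1O`: 2.7

In a physicochemical assay for lipophilicity, read by HPLC, at pH 7.4 (a higher number here means a more lipophilic compound, a lower number a more polar compound), compound 1 gives 1.9, the lower of the two actual numbers, and compound 3 gives 2.7, a gap beyond the scatter. Compound 4 `COCC/N=C1\S/C(=C\c2ccc(O)c(Cl)c2)C(=O)N1c1ccccc1C` differs from compound 1 in one place: methyl in place of hydrogen on an oxygen on a saturated carbon. This turns hydroxy into methoxy. Among the compounds with values here, only one measured step bears on it, and only indirectly: a number at least 1.60 log units lower from compound 2 to compound 3 (beyond the scatter). That large step brings in 2-hydroxyphenyl in place of isopropyl, elsewhere on the molecule, whereas here a hydroxy is lost. An upward change of smaller size is therefore expected, and the expected step is a number 1.20 log units higher from compound 1 to compound 4 (beyond the scatter). For compound 4 the estimated value is 3.1, with an expected range of 2.6 to 3.7.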

Compound 4, distribution coefficient: 2.9
The estimate for compound 4 lay 0.20 log units above the measured number; low and high end bracket the measured number.
By their numbers in this assay, from the lowest: compound 1; then compounds 3 and 4 (each within the scatter of the next). At a limit, above all of these: compound 2.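

In this assay, within the data shown here, 2-methoxyethyl in place of 2-hydroxyethyl gives a number 1.00 log units higher from compound 1 to compound 4 (beyond the scatter) and is the first step read at this position, since the earlier step lay elsewhere on the molecule. Methyl in place of hydrogen on this oxygen thus moves the number by a modest amount, beyond the scatter. Compound 2 stands at a limit and gives no number: the limit of > 4.3 in this assay, at which 1 of the 4 values shown sits.

Going by these compounds, what an amine or a carboxylic acid at the end of this chain would give stays open, as does a longer chain. On these data alone, whether the same change gives a similar step on the other compounds also stays open.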